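Ring amine substituent and transporter binding in the series

This account rests on a few compounds, and the source may have more. Where it says the series, first, only, none or still open, it means among the compounds named here.

compound 1 `OC1CNCCC1N1CCN(c2ccccc2)CC1`: 100 nM
compound 2 `OC1CN(Cc2ccc(Br)cc2)CCC1N1CCN(c2ccccc2)CC1`: > 100 nM

In an assay on PC-12 cells for displacement of a labelled ligand from vesicular acetylcholine transporter (Homo sapiens) (on this read-out lower numbers stand for stronger inhibition and higher numbers for weaker inhibition), compound 1 gives 100 nM. For compound 2 only a limit is known, > 100 nM. Compound 2 thus sits at the limit of > 100 nM in this assay, at which 1 of the 2 values shown sits. For the measured compounds named here, the one relevant step, a number no lower from compound 1 to compound 2 (the limit leaves the size open), is open in size and in direction beyond "no lower".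

Compound 3 `CCN1CCC(N2CCN(c3ccccc3)CC2)C(O)C1` differs from compound 2 by methyl in place of 4-bromophenyl on a saturated chain carbon bound to an amine nitrogen in a ring. With the ethyl much smaller than the 4-bromobenzyl, the step that the limit leaves unreadable from compound 2 to compound 3 is expected to be small or toward stronger binding, but its size is uncertain. Compound 3 is estimated at 200 nM, within 60 nM to 700 nM.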

Compound 3, half-maximal inhibitory concentration: > 1000 nM
Compound 3: a limit, no number (the forecaster's own chance of this, stated with the estimate: 35%); middle value at least 5.0-fold (0.69 log units) away from the limit.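

Ethyl in place of hydrogen on the amine nitrogen in a ring gives an at least 10-fold higher number from compound 1 to compound 3 (1.00 log units; beyond the scatter), the first readable step at this position, and it shows that even this small substituent weakens binding beyond the scatter. For compound 3, the value > 1000 nM is a limit. Compound 2 and compound 3 both carry limits, so the step between them cannot be read.

Open, on these data alone, is how an acetyl or a plain benzyl on the same nitrogen would compare with compound 1. As far as these compounds go, the true values behind both limits also remain open.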